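A few compounds are considered here, and "the series" means these few. Any claim that something is new, unique, unknown or untested is made for them only; others in the source may bear on it.

Working notes on the series: in a physicochemical assay for solubility, read by turbidimetry, measured as kinetic solubility, at pH 7.4 (a lower number here means a less soluble compound, a higher number a more soluble compound), compound 1 (`COc1ccccc1N1C(=O)CSC1c1cc(F)cc(C(=O)NCCCCc2ccccc2)c1`) gives 10000 nM, compound 2 (`C#Cc1cc(C(=O)NCCCCc2ccccc2)cc(C2SCC(=O)N2c2ccccc2OC)c1`) gives 10000 nM and compound 3 (`O=C(NCCCCc1ccccc1)c1cccc(C2SCC(=O)N2c2cccc(-c3c[nH]nn3)c2)c1`) gives 20000 nM. Compound 3 therefore stands within the scatter of both other compounds.

The next structure is compound 4 (`CC(F)(F)c1cccc(N2C(=O)CSC2c2cccc(C(=O)NCCCCc3ccccc3)c2)c1`), where 1,1-difluoroethyl replaces 1H-1,2,3-triazol-4-yl on an aromatic carbon: 1,1-difluoroethyl in place of 1H-1,2,3-triazol-4-yl on an aromatic carbon.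

Among the measured compounds shown here, the only measured step is ethynyl in place of fluoro on an aromatic carbon: no change at the digits printed from compound 1 to compound 2 (within the scatter). It involves neither group in the present change, so it bears only indirectly, showing one substitution in this series with no change beyond the scatter. For the measured compounds named here, no measured step removes 1H-1,2,3-triazol-4-yl or introduces 1,1-difluoroethyl. The closest guide is compound 1 at 10000 nM, which lacks the triazolyl group, as does compound 2 at 10000 nM. A modest downward step, not clearly beyond the scatter, is therefore expected in this assay.

The estimated step is a 2.0-fold lower number from compound 3 to compound 4 (0.30 log units; within the scatter).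

For compound 4, the estimated value is 10000 nM, with an expected range of 4000 nM to 20000 nM.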

Compound 4, solubility: 2000 nM
Compound 4: the middle estimate sits 5.0-fold (0.70 log units) above what was measured, and the stated range ends above it.
By their numbers in this assay, from the lowest: compound 4; then compounds 1, 2 and 3 (each within the scatter of the next).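

Among the compounds shown here, on an aromatic carbon of a six-membered aromatic ring of carbon only, meta to a large group, 1,1-difluoroethyl in place of 1H-1,2,3-triazol-4-yl gives a 10-fold lower number from compound 3 to compound 4 (1.00 log units; beyond the scatter) in this assay and so provides the first step beyond the scatter. For the compounds shown here, the earlier step, no change at the digits printed from compound 1 to compound 2 (within the scatter) for ethynyl in place of fluoro, involves neither of these groups, and only this pair shows that a single replacement at this position can move the read-out beyond the scatter. No measurement on hand accounts for the size of this step.

A single pair cannot separate the departure of 1H-1,2,3-triazol-4-yl from the arrival of 1,1-difluoroethyl. From the compounds shown here alone, how a carboxylic acid or an amine at this position would read in this assay remains open.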